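A few compounds are considered here, and "the series" means these few. Any claim that something is new, unique, unknown or untested is made for them only; others in the source may bear on it.

In a functional assay on K562 cells (Homo sapiens) for cytotoxicity, read by trypan blue exclusion, with a stated time of 96 h (a lower number here means a stronger inhibitor, a higher number a weaker inhibitor), compound 1 (`O=S(=O)(/C=C/c1ccccc1)Nc1ccccc1`) gives 10000 nM, compound 2 (`COc1cc(OC)c(/C=C/S(=O)(=O)Nc2cc([N+](=O)[O-])c(OC)c([N+](=O)[O-])c2)c(OC)c1`) gives 10000 nM and compound 3 (`COc1ccc(NS(=O)(=O)/C=C/c2c(F)c(F)c(F)c(F)c2F)cc1`) gives 5000 nM. Compound 2 therefore stands level with compound 1, and all three lie within the usual scatter of one another. Compound 4 (`COc1cc(OC)c(/C=C/S(=O)(=O)Nc2ccc(OC)c([N+](=O)[O-])c2)c(OC)c1`) differs from compound 2 in one place, with hydrogen in place of nitro on an aromatic carbon, ortho to a methoxy group: hydrogen in place of nitro on an aromatic carbon. For the measured compounds named here, no measured pair shows this change, so the expectation that follows is loose. In this assay, a step to a lower number, larger than the scatter, is expected, estimated as a 20-fold lower number from compound 2 to compound 4 (1.30 log units; beyond the scatter). The estimate for compound 4 is 500 nM, with an expected range from 30 nM to 4000 nM.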

Compound 4, half-maximal inhibitory concentration: 1000 nM
Compound 4: middle estimate off by 2.0-fold (0.30 log units), on the low side; the range from low to high includes it.
By their numbers in this assay, from the lowest: compound 4; then compounds 3, 1 and 2 (each within the scatter of the next).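

In this assay there is a 10-fold lower number from compound 2 to compound 4 (1.00 log units; beyond the scatter) when hydrogen takes the place of nitro on this aromatic carbon, ortho to a methoxy group. For the compounds shown here, this is the first step between two compounds differing in one place, and it shows that what this carbon carries can matter beyond the scatter. Nothing measured here explains the step.

This single pair cannot show whether the same change would behave alike on another core. From the compounds shown here alone, how an amine or a carboxylic acid at this carbon would compare also stays open.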